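The compounds below may be only part of what the source reports. "The series", "measured", "known", "first", "only" and "open" are said of these compounds alone.

Compound 1 `CC1(C)OC(=O)C(=CNc2cccc([N+](=O)[O-])c2)C(=O)O1` gives > 250000 nM in an ADME assay on THP-1 cells (Homo sapiens) for cytotoxicity, read by flow cytometry and propidium iodide staining, with a stated time of 72 h (on this read-out lower numbers stand for stronger inhibition and higher numbers for weaker inhibition), which is a limit of the assay and not a number.
Compound 2 `CN(C)c1nc2ccc(NC=C3C(=O)OC(C)(C)OC3=O)cc2o1` gives > 250000 nM in this assay, likewise a limit of the assay.

Among the measured compounds shown here, compound 1 thus stands at the limit of the measured range, with no number of its own; the one other value shown is a limit as well, so that the limit of > 250000 nM in this assay, at which 2 of the 2 values shown sit, describes every result at hand. For the measured compounds named here, no step between two measured compounds exists here, and the shared core of compound 1 and compound 2 is carried unchanged into compound 3 `CC1(C)OC(=O)C(=CNc2cccc(-c3nc4ccccc4s3)c2)C(=O)O1`, which is yet to be measured.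

Compound 3 differs from compound 1 in one place: 1,3-benzothiazol-2-yl in place of nitro on an aromatic carbon. Going by the values given here, with both measured compounds sitting at the limit, there is no measured step on which to rest an expectation of direction, and the change itself brings no evidence of its own. The expected step of an at least 1.3-fold lower number from compound 1 to compound 3 (0.14 log units; that floor lies within the scatter) from compound 1 to compound 3 is therefore none beyond the scatter, though with a wider spread than usual. Compound 3 is estimated to give 180000 nM in this assay, within a range from 40000 nM to 250000 nM.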

Compound 3, half-maximal inhibitory concentration: 115000 nM
Beside the measured number, compound 3's estimate is 1.6-fold (0.19 log units) above it, and the stated range covers the measured number.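

Compound 3 is the only compound shown with a number of its own in this assay, so this place, meta to a large group on the six-membered aromatic ring, is one where a change in the group can bring the read-out inside the measured range: 1,3-benzothiazol-2-yl in place of nitro gives an at least 2.1-fold lower number from compound 1 to compound 3 (0.33 log units; beyond the scatter). On these data alone, compound 1 has only a limit of the assay and no number of its own, so the true size of this step stays unknown, and the set as a whole still rests largely on that limit: the limit of > 250000 nM in this assay, at which 2 of the 3 values shown sit. The two groups have the same counts of hydrogen-bond donors and acceptors and neither carries a net charge, so the step goes with the added aromatic rings and heavy atoms, although a single pair cannot show which of these matters.

As far as these compounds go, it remains open whether a plain phenyl ring, or a smaller group such as an amine or a carboxylic acid, would also bring the number down from the limit at this place. From the compounds shown here alone, it is also open whether 1,3-benzothiazol-2-yl would give a similar step elsewhere on the ring.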